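The source may report more compounds than this note shows. Statements on the series, on what has been measured and on what is new or still open speak of the compounds shown alone.

Within the data shown here, compound 1 `OCCNc1nccc2c1ncn2C1O[C@H](CO)[C@@H](O)[C@H]1O` gives 6% in a functional assay on EL4 cells (Mus musculus) for inhibition, tested at 100 uM (on this read-out lower numbers stand for less inhibition and higher numbers for more inhibition at the one concentration tested (going by the name of the read-out)), and is the only number recorded. Compound 2 `Nc1[nH]ccc2ncnc1-2` gives in this assay only a limit of the assay, < 5%, which is the limit of < 5% in this assay, at which 1 of the 2 values shown sits. Compound 3 `OC[C@H]1OC(n2cnc3c(Cl)nccc32)[C@H](O)[C@@H]1O` has not yet been measured in this assay. It differs from compound 1 by chloro in place of (2-hydroxyethyl)amino on an aromatic carbon. With one low reading and one limit at hand, the expected change is a number 1 percentage points lower from compound 1 to compound 3 (within the scatter), nothing beyond the usual scatter. In this assay compound 3 is estimated at 5%, between 0% and 15%, with a fair chance that only a limit is reported.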

Compound 3, a percentage reported as inhibition, at one concentration (the size of the read-out at that concentration, not a potency): < 5%
Compound 3: only a limit was reported; the forecaster's own chance of this, stated with the estimate: 45%; the middle value lies on the limit itself.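

In this assay, chloro in place of (2-hydroxyethyl)amino on an aromatic carbon, next to the ring nitrogen, gives a number at least 1 percentage points lower from compound 1 to compound 3 (that floor lies within the scatter). The value of compound 3, < 5%, is a limit of the assay and not a number. At this position, swapping the side chain for a single chlorine therefore yields no reading clear of the floor of the read-out, and most of the series now sits there: the limit of < 5% in this assay, at which 2 of the 3 values shown sit.

On these data alone, whether the two groups truly differ remains open. So does whether a carboxylic acid or an amine with a longer chain at this carbon would give inhibition beyond the scatter.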